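Swapping the ring-nitrogen substituent of compound 2

This account rests on a few compounds, and the source may have more. Where it says the series, first, only, none or still open, it means among the compounds named here.

Compound 2 `COc1cc(-c2nc3cc(/C=C4\SC(=O)N(CC(=O)N5CCCCC5)C4=O)ccc3[nH]2)cc(OC)c1OC` gives 980 nM in a functional assay on A549 cells (Homo sapiens) for inhibition, read by MTT assay, with a stated time of 48 h (a lower number here means a stronger inhibitor, a higher number a weaker inhibitor), the lowest of the three numbers seen; compound 1 `COc1cc(OC)c(-c2nc3cc(/C=C4\SC(=O)NC4=O)ccc3[nH]2)cc1OC` gives 1840 nM, within the scatter of compound 2, while compound 3 `COc1cc(OC)c(-c2nc3cc(/C=C4\SC(=O)N(CC(=O)N5CCCCC5)C4=O)ccc3[nH]2)cc1OC` gives 14500 nM. Compound 4 `COc1cc(-c2nc3cc(/C=C4\SC(=O)N(Cc5cccc(C)c5)C4=O)ccc3[nH]2)cc(OC)c1OC` differs from compound 2 by 3-methylphenyl in place of (piperidin-1-yl)carbonyl on a saturated chain carbon bound to an amide-type nitrogen in a ring. Of the measured steps, only a 7.9-fold higher number from compound 1 to compound 3 (0.90 log units; beyond the scatter) touches this nitrogen, showing that a group there can change the number; a 15-fold higher number from compound 2 to compound 3 (1.17 log units; beyond the scatter) concerns the methoxy pattern instead. Nothing measured carries a 3-methylbenzyl, so the direction is open and a modest step either way is expected, a 1.5-fold higher number from compound 2 to compound 4 (0.18 log units; within the scatter). Compound 4 is therefore estimated at 1500 nM, with a likely range from 400 nM to 6000 nM.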

Compound 4, half-maximal inhibitory concentration: 930 nM
Beside the measured number, compound 4's estimate is 1.6-fold (0.21 log units) above it; the measured number falls inside the stated range.
By their numbers in this assay, from the lowest: compounds 4, 2 and 1 (each within the scatter of the next); then compound 3.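

Replacing the ((piperidin-1-yl)carbonyl)methyl on this nitrogen with 3-methylbenzyl gives a 1.1-fold lower number from compound 2 to compound 4 (0.02 log units; within the scatter) in this assay. So, with the 3,4,5-trimethoxyphenyl group in place, a non-aromatic ring carrying a hydrogen-bond acceptor and an all-carbon aromatic ring with none are not told apart at this position. No available evidence bears on this result. Still open, going by these compounds, is whether an amine or a carboxylic acid on the same chain carbon would keep the number in this range, and whether a longer chain would do so.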